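The source may hold more compounds than are shown below. What is called first, only, known or untested is meant among the compounds shown, and "the series" means these compounds.

Measured so far:
Compound 1, `COC(=O)C1=C(C)NC(C)=C(C(=O)OCc2ccc(OC)cc2)C1c1cccc([N+](=O)[O-])c1`, gives 79 nM in a functional assay on HEK293 cells for antagonist activity at Voltage-dependent L-type calcium channel subunit alpha-1D (Rattus norvegicus), read by FLIPR; on this read-out lower numbers stand for stronger inhibition and higher numbers for weaker inhibition.
Compound 2, `COC(=O)C1=C(C)NC(C)=C(C(=O)OCCC(C)c2ccccc2)C1c1cccc([N+](=O)[O-])c1`, gives 11 nM in this assay.

Going by the values given here, of these two numbers, compound 2 stands lowest; its only neighbour is compound 1, separated by a 7.2-fold lower number from compound 1 to compound 2 (0.86 log units; beyond the scatter). Compound 3, `COC(=O)C1=C(C)NC(C)=C(C(=O)OCCCOc2ccccc2)C1c1cccc([N+](=O)[O-])c1`, is not yet measured. It differs from compound 2 in one place: phenoxymethyl in place of 1-phenylethyl on a saturated chain carbon, two bonds along the chain from an oxygen next to a carbonyl group. Among the compounds with values here, the single measured step, a 7.2-fold lower number from compound 1 to compound 2 (0.86 log units; beyond the scatter), alters the same ester chain and was modest in size, yet it concerns a different exchange, so it guides the new step only loosely. The chain in compound 3 keeps its length and gains one hydrogen-bond acceptor; with no closer comparison available, a step of small size is expected, most likely toward a somewhat higher number. Compound 3 is expected to give 20 nM, with a range from 6 nM to 70 nM. The expected step is a 1.8-fold higher number from compound 2 to compound 3 (0.26 log units; within the scatter), staying close to the scatter.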

Compound 3, half-maximal inhibitory concentration: 11 nM
Beside the measured number, compound 3's estimate is 1.8-fold (0.26 log units) above it; measured number inside the range.
By their numbers in this assay, from the lowest: compounds 2 and 3 (each within the scatter of the next); then compound 1.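

In this assay, phenoxymethyl in place of 1-phenylethyl on this saturated chain carbon gives no change at the digits printed from compound 2 to compound 3 (within the scatter), so at this place a chain oxygen and its added hydrogen-bond acceptor are tolerated with no measurable penalty. Seen from compound 1, the 2-phenoxyethyl chain gives a 7.2-fold lower number from compound 1 to compound 3 (0.86 log units; beyond the scatter) and the 2-phenylpropyl chain gives a 7.2-fold lower number from compound 1 to compound 2 (0.86 log units; beyond the scatter), so two different chains of equal heavy-atom count, each ending in a phenyl ring, both stand beyond the scatter from compound 1. No measurement at hand explains why these two chains read alike.

The compounds shown leave open whether a longer chain ending in a phenoxy group would still read like compound 2 and compound 3. On these data alone, it is equally open what an amine in the place of the chain oxygen would give.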